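The compounds below may be only part of what the source reports. "The series", "measured", "known", "first", "only" and "open" are said of these compounds alone.

Among the measured compounds shown here, compound 2 `CN1C(=O)S/C(=C\c2ccc(N)cc2)C1=O` gives 62000 nM in a functional assay on CCRF-CEM cells (Homo sapiens) for cytotoxicity, read by cell counting, with a stated time of 3 days (a lower number here means a stronger inhibitor, a higher number a weaker inhibitor), and holds the only plain number in the set. Compound 1 `Cc1ccc(CN2C(=O)S/C(=C\c3ccc(N)cc3)C2=O)cc1` sits at the limit of the assay, > 250000 nM. The step of an at least 4.0-fold lower number from compound 1 to compound 2 (0.60 log units; beyond the scatter) is the single measured reference, and it bears on (the limit of > 250000 nM in this assay, at which 1 of the 2 values shown sits). Compound 3 `Nc1ccc(/C=C2\SC(=O)N(Cc3ccccc3)C2=O)cc1` carries phenyl in place of hydrogen on a saturated chain carbon bound to an amide-type nitrogen in a ring, which reinstalls a ring at the position that compound 1 occupied with its 4-methylphenyl. On that basis a move toward a higher number, back toward the limit, is expected for compound 3, with a 2.4-fold higher number from compound 2 to compound 3 (0.38 log units; beyond the scatter). The estimate for compound 3 is 150000 nM, between 50000 nM and 400000 nM.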

Compound 3, half-maximal inhibitory concentration: 42000 nM
Estimate against measurement, compound 3: 3.6-fold (0.55 log units) above; measured number outside the range, below it.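

In this assay, the change from methyl to benzyl gives a 1.5-fold lower number from compound 2 to compound 3 (0.17 log units; within the scatter), so phenyl on the saturated chain carbon bound to an amide-type nitrogen in a ring leaves compound 3 level with compound 2. Adding a ring at this position does not by itself return the series to the limit, and the only change left between the other pair gives an at least 5.9-fold lower number from compound 1 to compound 3 (0.77 log units; beyond the scatter). That step has a limit at one end, the value of compound 1: the limit of > 250000 nM in this assay, at which 1 of the 3 values shown sits.

Still open, from the compounds shown here alone, is how an amine or a carboxylic acid on the phenyl would read, or a longer chain between the nitrogen and that ring. Also open, going by these compounds, is whether methyl on an aromatic carbon has the same consequence on any other core.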